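The compounds below may be only part of what the source reports. "The series", "measured", "known", "first", "only" and "open" are said of these compounds alone.

Measured compounds:
compound 1 `Fc1ccccc1/C=C/c1ccccc1` gives 700 nM
compound 2 `Cc1ccc(/C=C/c2ccc(F)cc2)cc1` gives 1300 nM
compound 3 `Cc1ccc(/C=C/c2ccccc2F)cc1` gives 1400 nM

In an assay on HepG2 cells for activation of nuclear factor erythroid 2-related factor 2 (Homo sapiens), read by a luciferase reporter, with a stated time of 5 h (a lower number here means that less compound is needed, a higher number that more compound is needed for the effect), compound 3 holds the highest of the three numbers, but its nearest neighbour is compound 2 and its furthest is compound 1, and both of those gaps lie within the scatter, so none of the three can be set apart from the others. Compound 4 `Cc1ccc(/C=C/c2ccc(F)cc2F)cc1` arises from compound 3 by fluoro in place of hydrogen on an aromatic carbon. Among the measured compounds shown here, the only step among the measured compounds, a 2.0-fold higher number from compound 1 to compound 3 (0.30 log units; within the scatter), concerns a methyl and not a fluoro, and it stayed within the scatter; it does not bear directly on the change at hand. Compounds 2 and 3 each carry one fluoro at different places: compound 2 shows 1300 nM and compound 3 shows 1400 nM, numbers that sit close together. For the measured compounds named here, with no step in this assay that adds a second fluoro, the expectation is a step of no more than the scatter in either direction, expressed as a 1.1-fold lower number from compound 3 to compound 4 (0.03 log units; within the scatter). Compound 4 is therefore estimated at 1300 nM, with a range from 600 nM to 3000 nM.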

Compound 4, half-maximal effective concentration: 2000 nM
Estimate against measurement, compound 4: 1.5-fold (0.19 log units) below; the range from low to high includes it.
By their numbers in this assay, from the lowest: compounds 1, 2, 3 and 4 (each within the scatter of the next, the first and the last beyond it).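

In this assay, fluoro in place of hydrogen on an aromatic carbon, meta to a fluoro group and para to a group of 9 heavy atoms, gives a 1.4-fold higher number from compound 3 to compound 4 (0.15 log units; within the scatter), so a second fluoro on this ring is tolerated here without a shift that can be told from the scatter. The comparison with the other single-fluoro compound gives a 1.5-fold higher number from compound 2 to compound 4 (0.19 log units; within the scatter), so compound 4 cannot be set apart from either of its two single-fluoro neighbours. Nothing available explains these steps.

As far as these compounds go, whether a different group at this position, such as an amine, a carboxylic acid or a longer chain, would give a step beyond the scatter remains open. From the compounds shown here alone, it is also open whether a third fluoro on the same ring would do so.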